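The source may hold more compounds than are shown below. What is called first, only, known or untested is meant among the compounds shown, and "the series" means these compounds.

Measured compounds:
- compound 1, `O=Cc1ccc(-c2cn3ccnc3c(-c3ccc4ncn(C5CCCCC5)c4c3)n2)cc1`, gives 37.8% in a functional assay on NCI-H460 cells (Homo sapiens) for inhibition, read by sulforhodamine B assay, with a stated time of 48 h, tested at 10 uM; a lower number here means less inhibition, a higher number more inhibition at the concentration tested (going by the name of the read-out)
- compound 2, `c1ccc2c(-c3cn4ccnc4c(-c4ccc5ncn(C6CCCCC6)c5c4)n3)cccc2c1`, gives 3.61% in this assay
- compound 3, `CC(=O)c1ccc(-c2cn3ccnc3c(-c3ccc4ncn(C5CCCCC5)c4c3)n2)cc1`, gives 7.12% in this assay

Compound 3 stands second highest of the three numbers. Its nearest neighbour is compound 2: a number 3.5 percentage points higher from compound 2 to compound 3 (within the scatter). Its furthest is compound 1: a number 30.7 percentage points lower from compound 1 to compound 3 (beyond the scatter), which is a large step from only a methyl entering on the carbonyl carbon. The other large step is a number 34.2 percentage points lower from compound 1 to compound 2 (beyond the scatter).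

Compound 4, `Clc1ccc(-c2cn3ccnc3c(-c3ccc4ncn(C5CCCCC5)c4c3)n2)cc1`, has not been measured. It differs from compound 3 in one place: chloro in place of acetyl on an aromatic carbon.

Going by the values given here, none of the measured steps swaps a chloro for an acetyl, so none bears directly on this change. What the measured steps show is that the two compounds without a formyl group, compound 2 and compound 3, both sit low and within the scatter of each other, while compound 1 sits far higher. Compound 4 also lacks the formyl group, so the expectation is that it stays in the low region, with a number 2.9 percentage points higher from compound 3 to compound 4 (within the scatter) expected to lie within the scatter. For compound 4 the estimate in this assay is 10%, with a range from 0% to 30%.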

Compound 4, a percentage reported as inhibition, at one concentration (the size of the read-out at that concentration, not a potency): 4.14%
Compound 4: middle estimate off by 5.9 percentage points, on the high side, and the stated range covers the measured number.
By their numbers in this assay, from the lowest: compounds 2, 4 and 3 (each within the scatter of the next); then compound 1.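

In this assay, replacing the acetyl with a chloro, a single chlorine atom in place of three heavy atoms and a double bond, leaves the number within the scatter: a number 3 percentage points lower from compound 3 to compound 4 (within the scatter). The same holds for the change of aryl group, a number 0.5 percentage points higher from compound 2 to compound 4 (within the scatter), whereas chloro in place of formyl gives a large step, a number 33.7 percentage points lower from compound 1 to compound 4 (beyond the scatter), so on this ring, para to a large group, three quite different substituents now read alike and only the formyl of compound 1 stands apart. No available evidence explains why the formyl compound differs from the other three.

On these data alone, it remains open whether the higher number needs the formyl group itself, or whether a hydroxymethyl, a carboxylic acid or a nitrile in the same place would also give it. Also open, as far as these compounds go, is whether a methoxy group or an amine there would stay with the low three.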